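Swapping Chloro for Fluoro on Two Different Cores

The source may report more compounds than this note shows. Statements on the series, on what has been measured and on what is new or still open speak of the compounds shown alone.

Compound 1 `CCc1nc(N)nc(N)c1-c1ccc2[nH]c(-c3ccc(Cl)cc3)[n+]([O-])c2c1` and compound 2 `CCc1nc(N)nc(N)c1-c1ccc2[nH]c(-c3ccc(F)cc3)[n+]([O-])c2c1` share one core and differ in a single place, namely fluoro in place of chloro on an aromatic carbon on the outer ring. In a functional assay on HCT-116 cells (Homo sapiens) for inhibition (on this read-out higher numbers stand for weaker inhibition of growth and lower numbers for stronger inhibition of growth), compound 1 gives 9000 nM and compound 2 gives 17000 nM in the same measurement, which makes a step of a 1.9-fold higher number from compound 1 to compound 2 (0.28 log units; within the scatter) between them. Compound 3 `Nc1ncc(-c2ccc(NCc3ccc(Cl)cc3)c([N+](=O)[O-])c2)cn1` is built on a different core, and how the two cores differ is not broken down here. In this assay compound 3 gives 3000 nM as the lowest number among the three measured compounds. Compound 4 `Nc1ncc(-c2ccc(NCc3ccc(F)cc3)c([N+](=O)[O-])c2)cn1` has not yet been measured; it differs from compound 3 in one place, namely fluoro in place of chloro on an aromatic carbon on its outer ring. Within the data shown here, the surroundings of the change read the same in both pairs, so this is the same change as the one between compound 1 and compound 2. Among the measured compounds shown here, that earlier step stayed within the scatter, so a similarly small step is expected here, resting on a 1.9-fold higher number from compound 1 to compound 2 (0.28 log units; within the scatter) as the only guide. The expected step is a 1.5-fold higher number from compound 3 to compound 4 (0.18 log units; within the scatter) in size. For compound 4 the estimate in this assay is 4500 nM with a range from 2000 nM to 10000 nM around it.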

Compound 4, concentration for 50% growth inhibition: 48000 nM
Beside the measured number, compound 4's estimate is 11-fold (1.03 log units) below it; the whole stated range lies below it.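

In this assay, putting fluoro in place of chloro on the core of compound 3 gives a 16-fold higher number from compound 3 to compound 4 (1.20 log units; beyond the scatter), a large step for an exchange of one halogen atom for another. This shows that the size of the step seen on one core cannot simply be carried over to the other, even though the change itself and its surroundings read the same in both pairs: the same change on two cores in this assay, a 1.9-fold higher number (0.28 log units; within the scatter) from compound 1 to compound 2 and a 16-fold higher number (1.20 log units; beyond the scatter) from compound 3 to compound 4, 8.5-fold (0.93 log units) apart, beyond the scatter of two such steps. Among these compounds, with only one pair on each core, this does not show why the two cores respond so differently, nor which of them a further core would resemble.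

Going by these compounds, only chloro and fluoro appear at this place, so it stays open whether compound 3 gains from having chloro or compound 4 loses from having fluoro. Bromo, methyl or plain hydrogen at the same place on both cores would show whether the gap between the two cores holds for other groups as well.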